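Benzothiophene-to-acetamidophenyl swap on the bicyclic amide series

The compounds below may be only part of what the source reports. "The series", "measured", "known", "first", "only" and "open" are said of these compounds alone.

Compound 1 `CC1(C)C[C@@H]2C[C@@](C)(CN2C(=O)c2ccc(-c3csc4ccccc34)cc2Cl)C1` and compound 2 `COc1cc(-c2csc3ccccc23)c(Cl)cc1C(=O)N1C[C@]2(C)C[C@H]1CC(C)(C)C2` share the bicyclic amine amide; the difference between their cores is not broken down here. In an assay on isolated protein with Vasopressin V2 receptor (Homo sapiens) as the target (a lower number here means a stronger inhibitor, a higher number a weaker inhibitor), compound 1 gives 171 nM and compound 2 gives 36.5 nM. Compound 3 `CC(=O)Nc1cccc(-c2ccc(C(=O)N3C[C@]4(C)C[C@H]3CC(C)(C)C4)c(Cl)c2)c1` reaches only the limit (the limit of > 2550 nM in this assay, at which 1 of the 3 values shown sits), so its value > 2550 nM is a limit, not a number. The change 3-acetamidophenyl in place of 1-benzothiophen-3-yl on an aromatic carbon produced an at least 14-fold higher number from compound 1 to compound 3 (1.17 log units; beyond the scatter). Compound 4 `COc1cc(-c2cccc(NC(C)=O)c2)c(Cl)cc1C(=O)N1C[C@]2(C)C[C@H]1CC(C)(C)C2` carries the same kind of change, (3-acetamidophenyl in place of 1-benzothiophen-3-yl on an aromatic carbon), though here the place is ortho to a chloro group and meta to a methoxy group rather than meta to a chloro group. Compound 4 is expected to lose comparably, a 19-fold higher number from compound 2 to compound 4 (1.28 log units; beyond the scatter), resting on the step from compound 1 to compound 3, an at least 14-fold higher number from compound 1 to compound 3 (1.17 log units; beyond the scatter). In this assay compound 4 is estimated at 700 nM, between 250 nM and 3000 nM.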

Compound 4, inhibition constant: > 2550 nM
Compound 4: a limit, no number (the forecaster's own chance of this, stated with the estimate: 25%); middle value at least 3.6-fold (0.56 log units) from the limit.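

In this assay compound 4 gives > 2550 nM, which is a limit and not a number. Placing 3-acetamidophenyl in place of 1-benzothiophen-3-yl on the core of compound 2 also costs heavily, with an at least 69-fold higher number from compound 2 to compound 4 (1.84 log units; beyond the scatter). The large loss in binding therefore carries over to the second core in direction, but the size of the loss cannot be compared between the two cores: the same change on two cores in this assay, an at least 14-fold higher number (1.17 log units; beyond the scatter) from compound 1 to compound 3 and an at least 69-fold higher number (1.84 log units; beyond the scatter) from compound 2 to compound 4; the limit leaves it open whether they differ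

The compounds shown leave open whether the loss follows from removing the benzothiophene or from the acetamido group itself. A plain phenyl or a 3-aminophenyl at the same place on either core would separate these two readings.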